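The source may hold more compounds than are shown below. What is called first, only, known or untested is meant among the compounds shown, and "the series" means these compounds.

Compound 1 `CC(C)(C)c1cc(NC(=O)Nc2ccc(-c3cn4ccncc4n3)cc2)no1`: 44.8 nM; compound 2 `CC(C)(C)c1cc(NC(=O)Nc2ccc(-c3cn4cccc(C(F)(F)F)c4n3)cc2)no1`: limit, > 900 nM; compound 3 `CC(C)(C)c1cc(NC(=O)Nc2ccc(-c3cn4ccc(Cl)cc4n3)cc2)no1`: 5.91 nM.

In a functional assay on MV4-11 cells (Homo sapiens) for cytotoxicity, read by MTT assay, with a stated time of 72 h (on this read-out higher numbers stand for weaker inhibition and lower numbers for stronger inhibition), compound 3 gives the lowest of the two numbers that were obtained. The nearest number is that of compound 1, which stands clearly higher, beyond the scatter of repeated measurements. For compound 2 the assay returned only a limit, > 900 nM, not a number. Compound 4 `COc1ccn2cc(-c3ccc(NC(=O)Nc4cc(C(C)(C)C)on4)cc3)nc2c1` differs from compound 3 in one place: methoxy in place of chloro on an aromatic carbon. Among the compounds with values here, no such step has been measured here. Compound 4 is expected to give 15 nM, between 4 nM and 60 nM. The estimated step of a 2.5-fold higher number from compound 3 to compound 4 (0.40 log units; beyond the scatter) is thus a modest rise in the number, close to the edge of the scatter, in the direction of weaker inhibition.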

Compound 4, half-maximal inhibitory concentration: 2.84 nM
For compound 4 the middle estimate is 5.3-fold (0.72 log units) above the measured one; measured number below the stated range.
By their numbers in this assay, from the lowest: compound 4; then compound 3; then compound 1. At a limit, above all of these: compound 2.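

In this assay methoxy in place of chloro gives a 2.1-fold lower number from compound 3 to compound 4 (0.32 log units; beyond the scatter) and so shows that this position, opposite the ring nitrogen, holds a low number with either group. Chloro is thus not needed there, and the hydrogen-bond acceptor that methoxy brings comes with no loss of inhibition. Nothing given here accounts for the size or direction of this step.

The compounds shown leave open how an amine, a carboxylic acid or a longer chain such as ethoxy would fare at this position. They also leave open whether plain hydrogen there would give a higher number than chloro or methoxy.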